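Swapping bromo for methoxy on the aniline ring

A few compounds are considered here, and "the series" means these few. Any claim that something is new, unique, unknown or untested is made for them only; others in the source may bear on it.

Measured so far:
- Compound 1 `COc1ccc(C(Nc2ccccc2)n2c(=O)ccc3cc(O)ccc32)cc1`: 46300 nM
- Compound 2 `COc1ccc(C(Nc2ccc(Br)cc2)n2c(=O)ccc3cc(O)ccc32)cc1`: 18300 nM

Of the compounds shown here, two have been tested in a functional assay on HepG2 cells (Homo sapiens) for inhibition, read by MTT assay; on this read-out lower numbers stand for stronger inhibition and higher numbers for weaker inhibition. Compound 1 `COc1ccc(C(Nc2ccccc2)n2c(=O)ccc3cc(O)ccc32)cc1` carries a plain phenylamino group and gives 46300 nM. Compound 2 `COc1ccc(C(Nc2ccc(Br)cc2)n2c(=O)ccc3cc(O)ccc32)cc1` carries bromo on that ring and gives 18300 nM, the lowest of the two numbers; the step of a 2.5-fold lower number from compound 1 to compound 2 (0.40 log units; beyond the scatter) was modest but beyond the scatter, so compound 2 is the stronger inhibitor of the pair.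

Compound 3 `COc1ccc(NC(c2ccc(OC)cc2)n2c(=O)ccc3cc(O)ccc32)cc1` has not been measured. It differs from compound 2 by methoxy in place of bromo on an aromatic carbon, para to a large group. Among the compounds with values here, only one step bears on this, from hydrogen to bromo, a 2.5-fold lower number from compound 1 to compound 2 (0.40 log units; beyond the scatter); nothing shows what methoxy does at this position. Replacing bromo by a different group is expected to lose part of that gain, so the step of a 1.5-fold higher number from compound 2 to compound 3 (0.18 log units; within the scatter) is estimated to be small and upward, staying near the scatter. Compound 3 is therefore expected to give about 28000 nM, with a range from 10000 nM to 70000 nM.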

Compound 3, half-maximal inhibitory concentration: 61400 nM
For compound 3 the middle estimate is 2.2-fold (0.34 log units) below the measured one; the range from low to high includes it.
By their numbers in this assay, from the lowest: compound 2; then compounds 1 and 3 (each within the scatter of the next).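

In this assay the gain seen with bromo does not extend to every group at this place on the aniline ring, since replacing bromo with methoxy gives a 3.4-fold higher number from compound 2 to compound 3 (0.53 log units; beyond the scatter) and that step lies beyond the scatter. Set against the unsubstituted ring, methoxy gives a 1.3-fold higher number from compound 1 to compound 3 (0.12 log units; within the scatter) and that step lies within the scatter, so compound 1 and compound 3 cannot be told apart and a substituent here does not by itself improve the number. No measurement available here explains why bromo and methoxy differ on this read-out.

The compounds shown leave open whether the gain belongs to bromo alone or is shared by other halogens such as chloro and fluoro, or by groups such as trifluoromethyl and nitrile. They also leave open how an amine or a carboxylic acid would behave at this place on the ring, and whether any group here could bring the number well below that of compound 2.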